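Chloro for Methyl on the Sulfonyl Arene

This account rests on a few compounds, and the source may have more. Where it says the series, first, only, none or still open, it means among the compounds named here.

Compound 1 `Cc1noc(C)c1S(=O)(=O)N1CCC(N2CCC(C)CC2)CC1`, compound 2 `CC1CCN(C2CCN(S(=O)(=O)c3ccccc3Br)CC2)CC1` and compound 3 `Cc1cccc(S(=O)(=O)N2CCC(N3CCC(C)CC3)CC2)c1` share one core and differ only in the group on the sulfonyl sulfur. In a functional assay on DLD-1 cells (Homo sapiens) for antiproliferative activity, read by CellTiter-Glo, with a stated time of 72 h (a lower number here means a stronger inhibitor, a higher number a weaker inhibitor), compound 1 gives no number but only a limit, > 5000 nM, which is the limit of the assay (the limit of > 5000 nM in this assay, at which 1 of the 3 values shown sits). In this assay compound 2 gives 3 nM. Compound 3 gives 25 nM in this assay. The steps of an at least 1600-fold lower number from compound 1 to compound 2 (3.22 log units; beyond the scatter) and an at least 200-fold lower number from compound 1 to compound 3 (2.30 log units; beyond the scatter) are both large, while an 8.3-fold higher number from compound 2 to compound 3 (0.92 log units; beyond the scatter) is modest. Of the two numbers shown, compound 3 stands highest, with compound 2 nearest. Compound 4 `CC1CCN(C2CCN(S(=O)(=O)c3cccc(Cl)c3)CC2)CC1` differs from compound 3 by chloro in place of methyl on an aromatic carbon. Going by the values given here, the steps that bear on this change are those on the sulfonyl aryl group: the large ones from compound 1 show that the aryl group matters greatly, but the modest one from 2-bromophenyl to 3-methylphenyl is the nearer guide, and a single-atom swap of chloro for methyl is expected to move this assay little, if at all, beyond the scatter. Compound 4 is therefore estimated at 18 nM, between 5 nM and 70 nM, an expected step of a 1.4-fold lower number from compound 3 to compound 4 (0.14 log units; within the scatter).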

Compound 4, half-maximal inhibitory concentration: > 5000 nM
Compound 4 gave a limit, no number; the forecaster's own chance of this, stated with the estimate: 3%; middle value at least 270-fold (2.44 log units) away from the limit.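

Going by these compounds alone, the swap of one heavy atom for another, chloro in place of methyl on an aromatic carbon, produces an at least 200-fold higher number from compound 3 to compound 4 (2.30 log units; beyond the scatter), so a change this small at this place can decide the whole result, which the earlier compounds did not show. A halogen on the phenyl ring does not in itself secure a low number either, given an at least 1600-fold higher number from compound 2 to compound 4 (3.22 log units; beyond the scatter), while the step from compound 1 to compound 4 cannot be read, as both values are limits. Compound 4 stands at a limit of this assay, not at a number: the limit of > 5000 nM in this assay, at which 2 of the 4 values shown sit.

Going by these compounds, it remains open whether the loss belongs to chloro alone or would also follow fluoro, methoxy or trifluoromethyl at this place. Also open, on these data alone, is where an unsubstituted phenyl group would stand, and whether bromo on this carbon would follow chloro or methyl.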